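The compounds below may be only part of what the source reports. "The series", "measured", "known", "first", "only" and "open" are said of these compounds alone.

Measured compounds:
compound 1 `N#CSc1c(-c2ccccc2)nc2sc(Cc3ccccc3)nn12` with 6000 nM
compound 2 `COc1ccc(-c2nc3sc(Cc4ccccc4)nn3c2SC#N)cc1` with 4600 nM
compound 3 `O=Cc1c(-c2ccc([N+](=O)[O-])cc2)nc2sc(Cc3ccccc3)nn12` with 2900 nM

In a functional assay on NSCLC cells (Homo sapiens) for inhibition (on this read-out higher numbers stand for weaker inhibition of growth and lower numbers for stronger inhibition of growth), compound 3 gives the lowest number of the three. Compound 2 lies within the scatter of compound 3, so the two cannot be ranked; compound 1 gives a number beyond the scatter above that of compound 3. Going by the values given here, the only measured step, a 1.3-fold lower number from compound 1 to compound 2 (0.12 log units; within the scatter), concerns a change on the phenyl ring and does not touch the five-membered ring.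

Compound 4 `O=[N+]([O-])c1ccc(-c2nc3sc(Cc4ccccc4)nn3c2Br)cc1` differs from compound 3 by bromo in place of formyl on an aromatic carbon. Among the compounds with values here, no measured step bears on this exchange: nothing among the three compounds replaces a formyl, and nothing varies this ring position. With no guide from the data, the expectation for compound 4 in this assay is a step of a 1.0-fold higher number from compound 3 to compound 4 (0.01 log units; within the scatter), that is none beyond the scatter, with a wide range to reflect the missing precedent. Compound 4 is thus estimated at 3000 nM, between 1200 nM and 8000 nM.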

Compound 4, concentration for 50% growth inhibition: 12600 nM
Estimate against measurement, compound 4: 4.2-fold (0.62 log units) below; the measured number lies above the stated range.
By their numbers in this assay, from the lowest: compounds 3, 2 and 1 (each within the scatter of the next, the first and the last beyond it); then compound 4.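

In this assay, bromo in place of formyl on an aromatic carbon of the five-membered aromatic ring, next to the ring nitrogen, gives a 4.3-fold higher number from compound 3 to compound 4 (0.64 log units; beyond the scatter). Going by these compounds alone, the only earlier step lay on the phenyl ring and within the scatter, so this is the first sign that the group at this position can change growth inhibition, here weakening it when formyl gives way to bromo. No measurement at hand explains why this exchange has that effect.

The compounds shown leave open how an amine, a carboxylic acid or a longer chain would fare at this position. They also leave open whether the same step would appear with an unsubstituted phenyl ring in place of the nitro-bearing one.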